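Trifluoromethoxy for trifluoromethyl on the aryl ether branch

The source may hold more compounds than are shown below. What is called first, only, known or untested is meant among the compounds shown, and "the series" means these compounds.

Compound 1 `CC(O)(CSc1ccc(C(F)(F)F)cc1)C(=O)Nc1ccc(S(F)(F)(F)(F)F)cc1` gives 14800 nM in a functional assay on CWR22R cells (Homo sapiens) for antiproliferative activity, read by propidium iodide staining, with a stated time of 96 h; on this read-out higher numbers stand for weaker inhibition and lower numbers for stronger inhibition. Compound 2 `CC(O)(CSc1ccc(OC(F)(F)F)cc1)C(=O)Nc1ccc(S(F)(F)(F)(F)F)cc1` gives 14900 nM in this assay. The change is trifluoromethoxy in place of trifluoromethyl on an aromatic carbon, and the step is a 1.0-fold higher number from compound 1 to compound 2 (0.00 log units; within the scatter). Compound 3 `CC(O)(COc1cccc(C(F)(F)F)c1)C(=O)Nc1ccc(S(F)(F)(F)(F)F)cc1` gives 14600 nM in this assay; the difference between the core of compound 3 and the core of compound 1 is not broken down here. Compound 4 `CC(O)(COc1cccc(OC(F)(F)F)c1)C(=O)Nc1ccc(S(F)(F)(F)(F)F)cc1` is the same kind of change applied to compound 3: trifluoromethoxy in place of trifluoromethyl on an aromatic carbon. In compound 1 the place is para to a large group, in compound 3 it is meta to a large group, so the change is the same kind, not the same. Beside the step measured from compound 1 to compound 2, the step from compound 3 to compound 4 is expected to be a 1.0-fold higher number from compound 3 to compound 4 (0.00 log units; within the scatter). Compound 4 is estimated at 14700 nM, between 8000 nM and 27000 nM, because the step of a 1.0-fold higher number from compound 1 to compound 2 (0.00 log units; within the scatter) is within the scatter.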

Compound 4, half-maximal inhibitory concentration: 17300 nM
For compound 4 the middle estimate is 1.2-fold (0.07 log units) below the measured one, and the stated range covers the measured number.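

Trifluoromethoxy in place of trifluoromethyl on the core of compound 3 gives a 1.2-fold higher number from compound 3 to compound 4 (0.07 log units; within the scatter). In this assay, within the data shown here, the change therefore reads the same on both cores, with neither step beyond the scatter: the same change on two cores in this assay, a 1.0-fold higher number (0.00 log units; within the scatter) from compound 1 to compound 2 and a 1.2-fold higher number (0.07 log units; within the scatter) from compound 3 to compound 4, 1.2-fold (0.07 log units) apart, within the scatter of two such steps This shows only that the exchange of these two groups is silent on these two cores, each at its own place on the ring. It does not show that the change would stay silent on another core or at another place, and the two cores differ in more than this position, so core and place cannot be separated here.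

Open, as far as these compounds go, is whether a nitrile, an amine or a carboxylic acid in the place of trifluoromethyl would move the number beyond the scatter. Also open, from the compounds shown here alone, is whether a longer chain between the aromatic ring and the carbon bearing the hydroxyl would do so.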